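The source may report more compounds than this note shows. Statements on the series, on what has been measured and on what is new or still open speak of the compounds shown alone.

Measured in an ADME assay on liver for metabolic stability, with Liver microsome (Homo sapiens) as the target, read by LC-MS, using microsomes, with a stated time of 5 h; on this read-out higher numbers stand for fast clearance and lower numbers for slow clearance:
compound 1 `O[C@H](c1ccccn1)[C@]1(c2cccc(OC(F)(F)F)c2)C[C@@H](O)C1`: 117 mL/min/kg
compound 2 `O[C@H](c1ccccn1)[C@]1(c2cccc(OC(F)(F)F)c2)C[C@H](O)C1`: 150 mL/min/kg
compound 3 `C[C@]1(c2ccc(OC(F)(F)F)cc2)C[C@@](O)(c2ccccn2)CO1`: 117 mL/min/kg

Compound 2 cannot be told apart from compound 1 and compound 3, since all three values lie within the scatter of one another. Compound 4 `O[C@H](c1ccccn1)[C@]1(c2cccc(C(F)(F)F)c2)C[C@H](O)C1` differs from compound 2 at one place: trifluoromethyl in place of trifluoromethoxy on an aromatic carbon. For the measured compounds named here, no measured step covers this exchange. Going by the values given here, the only step available, a 1.3-fold higher number from compound 1 to compound 2 (0.11 log units; within the scatter), lies within the scatter and reflects (the fact that compounds 1 and 2 differ only in the configuration as drawn), so it bears on the exchange only indirectly. No step beyond the scatter is therefore expected in this assay, in either direction. The estimate amounts to a 1.2-fold lower number from compound 2 to compound 4 (0.08 log units; within the scatter), an expected step within the scatter. For compound 4 the estimated clearance is 125 mL/min/kg, with an expected range of 65 mL/min/kg to 240 mL/min/kg.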

Compound 4, clearance: 133 mL/min/kg
The estimate for compound 4 lay 1.1-fold (0.03 log units) below the measured number, and the stated range covers the measured number.
By their numbers in this assay, from the lowest: compounds 1, 3, 4 and 2 (each within the scatter of the next).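

In this assay, trifluoromethyl in place of trifluoromethoxy on the aromatic carbon gives a 1.1-fold lower number from compound 2 to compound 4 (0.05 log units; within the scatter), so this exchange, which removes the oxygen and one hydrogen-bond acceptor, produces no readable change in clearance at this position. For the compounds shown here, nothing among the available evidence bears on this exchange, as the only measured comparison concerns configuration alone. Going by these compounds, whether an amine, a carboxylic acid or a longer chain on this aromatic carbon would give a step beyond the scatter stays open. So does the outcome of the same exchange in the configuration of compound 1.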